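A Sulfonyl Pyrrolidine Replaces the Piperidine of Compound 3

A few compounds are considered here, and "the series" means these few. Any claim that something is new, unique, unknown or untested is made for them only; others in the source may bear on it.

Compound 1 `CN1CCN(c2ccc(Nc3ncc4nc(Nc5ccc(F)cc5)n([C@@H]5CCN(C(=O)CO)C5)c4n3)cc2)CC1`: 350 nM
Compound 2 `CN1CCN(c2ccc(Nc3ncc4nc(Nc5ccc(F)cc5)n([C@H]5CCN(C(=O)OC(C)(C)C)C5)c4n3)cc2)CC1`: 580 nM
Compound 3 `CN1CCN(c2ccc(Nc3ncc4nc(Nc5ccc(F)cc5)n([C@@H]5CCCNC5)c4n3)cc2)CC1`: 120 nM

All three values come from a functional assay on HCC827 cells (Homo sapiens) for antiproliferative activity, read by MTT assay, with a stated time of 72 h; on this read-out lower numbers stand for stronger inhibition and higher numbers for weaker inhibition. Compound 3 has the lowest number of the three, and its steps to both others lie beyond the scatter. Compound 4 `CN1CCN(c2ccc(Nc3ncc4nc(Nc5ccc(F)cc5)n([C@H]5CCN(S(=O)(=O)C6CC6)C5)c4n3)cc2)CC1` has yet to be measured in this assay. Its difference from compound 3 is 1-(cyclopropylsulfonyl)pyrrolidin-3-yl in place of piperidin-3-yl on an aromatic nitrogen.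

Among the compounds with values here, two measured steps bear most directly on this change, since each joins a substituted pyrrolidin-3-yl compound to the piperidin-3-yl compound: a 2.9-fold lower number from compound 1 to compound 3 (0.46 log units; beyond the scatter) and a 4.8-fold lower number from compound 2 to compound 3 (0.68 log units; beyond the scatter). Both are modest. The step between the two pyrrolidin-3-yl compounds, a 1.7-fold higher number from compound 1 to compound 2 (0.22 log units; within the scatter), stays within the scatter. Within the data shown here, no measured compound carries the cyclopropylsulfonyl group, so this reading is only an analogy. Running the same kind of change in reverse, a modest step to a higher number is expected. The estimated step is a 3.3-fold higher number from compound 3 to compound 4 (0.52 log units; beyond the scatter). For compound 4 the expected value is 400 nM, with an estimated range from 150 nM to 1000 nM.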

Compound 4, half-maximal inhibitory concentration: 7.5 nM
For compound 4 the middle estimate is 53-fold (1.73 log units) above the measured one; the whole stated range lies above it.
By their numbers in this assay, from the lowest: compound 4; then compound 3; then compounds 1 and 2 (each within the scatter of the next).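

Before compound 4, both substituted pyrrolidin-3-yl compounds in this assay stood above the piperidin-3-yl compound, yet the cyclopropylsulfonyl group on the same five-membered ring reverses that order, with a 16-fold lower number from compound 3 to compound 4 (1.20 log units; beyond the scatter) and compound 4 the lowest of the four. The group on the ring nitrogen therefore matters far more at this position than the earlier pair suggested: tert-butoxycarbonyl and (hydroxymethyl)carbonyl gave only a 1.7-fold higher number from compound 1 to compound 2 (0.22 log units; within the scatter) within the scatter, whereas the sulfonyl group gives a 77-fold lower number from compound 2 to compound 4 (1.89 log units; beyond the scatter) and a 47-fold lower number from compound 1 to compound 4 (1.67 log units; beyond the scatter) on the same ring. A pyrrolidin-3-yl group on the aromatic nitrogen is thus compatible with the lowest number in this set. Nothing among the data given accounts for the size of this gain.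

The compounds shown leave open whether the gain belongs to the sulfonyl link or to the cyclopropyl ring, which a cyclopropylcarbonyl or a methylsulfonyl group on the same nitrogen would separate. They also leave open how much the ring itself contributes, a question that 1-(cyclopropylsulfonyl)piperidin-3-yl would address directly.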